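A few compounds are considered here, and "the series" means these few. Any claim that something is new, unique, unknown or untested is made for them only; others in the source may bear on it.

In a functional assay on HeLa cells (Homo sapiens) for cytotoxicity, read by MTT assay, with a stated time of 24 h (a higher number here means a weaker inhibitor, a lower number a stronger inhibitor), two compounds have been measured so far. Compound 1 (`COc1ccc(/C=C2\CN(C)C/C(=C\c3ccccc3F)C2=O)cc1`) gives 23500 nM as its half-maximal inhibitory concentration, and compound 2 (`COc1cc(/C=C2\CN(C)C/C(=C\c3ccccc3F)C2=O)cc(OC)c1`) gives 5450 nM as its own. Compound 2 therefore holds the lower of the two numbers, and the gap lies beyond the usual scatter of repeated measurements, which makes it the stronger inhibitor of this pair.

The next compound to be measured is compound 3 (`COc1cc(/C=C2\CN(C)C/C(=C\c3cccc([N+](=O)[O-])c3)C2=O)cc(OC)c1`). It differs from compound 2 in one place: 3-nitrophenyl in place of 2-fluorophenyl on a double-bonded chain carbon bound to a double-bonded ring carbon. Among the measured compounds shown here, no measured pair yet shows what such an exchange does to the number. The main guide is the level of compound 2 at 5450 nM in the same measurement, so only a modest change is expected. The estimated 1.4-fold lower number from compound 2 to compound 3 (0.13 log units; within the scatter) points toward a slightly stronger inhibitor and stays within the scatter. In this assay compound 3 is estimated at 4000 nM with an expected range from 1300 nM to 13000 nM as the likely span.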

Compound 3, half-maximal inhibitory concentration: 2560 nM
Beside the measured number, compound 3's estimate is 1.6-fold (0.19 log units) above it; the range from low to high includes it.
By their numbers in this assay, from the lowest: compound 3; then compound 2; then compound 1.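

In this assay, 3-nitrophenyl in place of 2-fluorophenyl gives a 2.1-fold lower number from compound 2 to compound 3 (0.33 log units; beyond the scatter), a modest step, but one that lies beyond the scatter. Among the compounds shown here, this is the first sign that the position, on a double-bonded chain carbon bound to a double-bonded ring carbon, responds to the group it carries: the rest of compound 2 stays the same, and both groups are built on a six-membered aromatic ring of carbon only, so the difference lies in what that ring bears. Nothing available here shows whether the step comes from the fluorine leaving or from the nitro group entering, and no measurement explains it.

The compounds shown leave open how a plain phenyl, a 3-aminophenyl or a 3-carboxyphenyl group would compare at this position, and such groups would help show whether the nitro group itself matters. They also leave open whether the same exchange would give a similar step on compound 1, which carries a different methoxy arrangement at the other end of the shared core.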